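Moving a hydroxyl on one arm of the shared core

The source may report more compounds than this note shows. Statements on the series, on what has been measured and on what is new or still open speak of the compounds shown alone.

Compound 1 `Oc1cccc(-c2cc(-c3cccc(F)c3)cc(-c3ccccc3O)n2)c1`: > 50000 nM
Compound 2 `Oc1cccc(-c2cc(-c3cccc(C(F)(F)F)c3)cc(-c3ccccc3O)n2)c1`: 13000 nM
Compound 3 `Oc1ccccc1-c1cc(-c2cccc(OC(F)(F)F)c2)cc(-c2ccccc2O)n1`: 7470 nM

In a functional assay on DU-145 cells (Homo sapiens) for inhibition (a lower number here means a stronger inhibitor, a higher number a weaker inhibitor), compound 3 gives 7470 nM, the lowest of the two plain numbers shown. Compound 2 gives 13000 nM, which lies within the scatter of compound 3. For compound 1 only a limit is reported, > 50000 nM, as recorded in the limit of > 50000 nM in this assay, at which 1 of the 3 values shown sits.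

Among the compounds with values here, the single measured step, an at least 3.8-fold lower number from compound 1 to compound 2 (0.58 log units; beyond the scatter), concerns the ring that carries the fluoro or trifluoromethyl group, not a hydroxyphenyl arm. Compound 4 `Oc1cccc(-c2cc(-c3cccc(OC(F)(F)F)c3)cc(-c3ccccc3O)n2)c1` differs from compound 3 in 3-hydroxyphenyl in place of 2-hydroxyphenyl on an aromatic carbon. No measured pair changes a hydroxyphenyl arm, so this step has no direct precedent among the compounds shown; the expectation is a step of no size beyond the scatter, in no particular direction.

Compound 4 is therefore estimated at 9000 nM, with a range from 3000 nM to 30000 nM. The step this estimate implies, a 1.2-fold higher number from compound 3 to compound 4 (0.08 log units; within the scatter), is expected to stay within the scatter.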

Compound 4, half-maximal inhibitory concentration: > 50000 nM
Compound 4 was reported as a limit (the forecaster's own chance of this, stated with the estimate: 15%); middle value at least 5.5-fold (0.74 log units) from the limit.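

Swapping 2-hydroxyphenyl for 3-hydroxyphenyl on the carbon next to the ring nitrogen keeps the same atoms but joins them differently, and in this assay this gives an at least 6.6-fold higher number from compound 3 to compound 4 (0.82 log units; beyond the scatter), so the position of the hydroxyl on this arm matters. With the 3-hydroxyphenyl arm kept, the group on the other ring also counts, as trifluoromethoxy in place of trifluoromethyl gives an at least 3.8-fold higher number from compound 2 to compound 4 (0.58 log units; beyond the scatter). Compound 4 is reported only as a limit, and the step from compound 1 to compound 4 cannot be read, as both compounds sit at the same limit: the limit of > 50000 nM in this assay, at which 2 of the 4 values shown sit.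

Going by these compounds, it remains open how a methoxy group or an amine in place of the hydroxyl on this arm would read. Also open, on these data alone, is whether 2-hydroxyphenyl would give a lower number with fluoro or trifluoromethyl on the other ring.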